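Bromo on the indole of the fused core: compound 3 to 4

This account rests on a few compounds, and the source may have more. Where it says the series, first, only, none or still open, it means among the compounds named here.

Measured compounds:
compound 1, `COC(=O)[C@@]1(C)CCC=C2[C@@H]1CC[C@@H](C)[C@]2(C)Cc1c[nH]c2c(Cl)cccc12`, 14000 nM
compound 2, `COC(=O)[C@@]1(C)CCC=C2[C@@H]1CC[C@@H](C)[C@]2(C)Cc1c(C)n(C(c2ccccc2)c2ccccc2)c2ccc(Cl)cc12`, see below
compound 3, `COC(=O)[C@@]1(C)CC[C@@H]2C3=C1CC[C@@H](C)[C@]3(C)Cc1c2[nH]c2ccccc12`, 8300 nM

In a functional assay on SW1573 cells (Homo sapiens) for inhibition, read by sulforhodamine B assay, with a stated time of 48 h (on this read-out lower numbers stand for stronger inhibition of growth and higher numbers for weaker inhibition of growth), compound 1 gives 14000 nM. For compound 2 this assay reports only a limit, > 100000 nM, which is a limit and not a number (the limit of > 100000 nM in this assay, at which 1 of the 3 values shown sits). Compound 3 gives 8300 nM in this assay, the lower of the two numbers, though the gap to compound 1 is within the scatter, so no order between compound 3 and compound 1 is claimed.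

Compound 4, `COC(=O)[C@@]1(C)CC[C@@H]2C3=C1CC[C@@H](C)[C@]3(C)Cc1c2[nH]c2ccc(Br)cc12`, is not yet measured. It differs from compound 3 in one place: bromo in place of hydrogen on an aromatic carbon. Going by the values given here, no measured pair shows this change, so there is no step to lean on. The expectation is a step from compound 3 to compound 4 of a 1.4-fold lower number from compound 3 to compound 4 (0.14 log units; within the scatter), a small move towards stronger inhibition of growth, hardly beyond the scatter. Compound 4 is therefore estimated at 6000 nM in this assay, within a range from 2000 nM to 20000 nM.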

Compound 4, concentration for 50% growth inhibition: 12000 nM
Beside the measured number, compound 4's estimate is 2.0-fold (0.30 log units) below it, and the stated range covers the measured number.
By their numbers in this assay, from the lowest: compounds 3, 4 and 1 (each within the scatter of the next). At a limit, above all of these: compound 2.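

In this assay bromo in place of hydrogen on this aromatic carbon, meta to a fused ring and para to a fused ring, gives a 1.4-fold higher number from compound 3 to compound 4 (0.16 log units; within the scatter) and so leaves no change that can be told from the scatter. Going by these compounds alone, this is the first step between two compounds differing in one place, and it shows that the fused core tolerates a bromine atom here, with no gain in inhibition of growth to be read from it. Nothing in the evidence at hand bears on this step.

On these data alone, whether an amine, a carboxylic acid or a methoxy group at this carbon would move the number beyond the scatter stays open. So does the outcome of bromo on the other aromatic carbons of this ring.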